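This account rests on a few compounds, and the source may have more. Where it says the series, first, only, none or still open, it means among the compounds named here.

Measured in a functional assay on A549 cells (Homo sapiens) for inhibition, read by CCK-8 assay, with a stated time of 48 h; a lower number here means a stronger inhibitor, a higher number a weaker inhibitor:
compound 1 `COc1cc(-c2ccnc3cc(-c4ccc(C)cc4)nn23)cc(OC)c1OC`: 3 nM
compound 2 `COc1cc(-c2ccnc3cc(-c4ccc(C(C)=O)cc4)nn23)cc(OC)c1OC`: 4100 nM
compound 3 `COc1cc(-c2ccnc3cc(-c4ccc5cnn(C)c5c4)nn23)cc(OC)c1OC`: 233 nM

Compound 3 holds the second highest of the three numbers, with 233 nM. It lies between its two neighbours: an 18-fold lower number from compound 2 to compound 3 (1.25 log units; beyond the scatter), and a 78-fold higher number from compound 1 to compound 3 (1.89 log units; beyond the scatter).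

Next is compound 4 `COc1ccc(-c2cc3nccc(-c4cc(OC)c(OC)c(OC)c4)n3n2)cc1N`, which shares the core of compound 3. The change is 3-amino-4-methoxyphenyl in place of 1-methyl-1H-indazol-6-yl on an aromatic carbon; 3-amino-4-methoxyphenyl takes the place of 1-methyl-1H-indazol-6-yl, so a single six-membered aromatic ring of carbon only returns at this carbon.

Among the measured compounds shown here, three measured steps bear on this. The step of a 78-fold higher number from compound 1 to compound 3 (1.89 log units; beyond the scatter) favours the 4-methylphenyl group over the 1-methyl-1H-indazol-6-yl group. The step of an 18-fold lower number from compound 2 to compound 3 (1.25 log units; beyond the scatter) goes the other way for the 4-acetylphenyl group. The step of a 1400-fold higher number from compound 1 to compound 2 (3.14 log units; beyond the scatter) shows how far one substituent on that ring can move the number. For the measured compounds named here, no measured compound carries the amino or methoxy groups on this ring, so the evidence is indirect and the range must stay wide.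

A large step towards a lower number is expected, though not the full distance to compound 1: a 9.3-fold lower number from compound 3 to compound 4 (0.97 log units; beyond the scatter) is the estimated step. For compound 4 the estimated value is 25 nM, with an expected range of 3 nM to 250 nM.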

Compound 4, half-maximal inhibitory concentration: 138 nM
Compound 4: the middle estimate sits 5.5-fold (0.74 log units) below what was measured; low and high end bracket the measured number.
By their numbers in this assay, from the lowest: compound 1; then compounds 4 and 3 (each within the scatter of the next); then compound 2.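

In this assay the return to a single six-membered aromatic ring of carbon only does not separate 3-amino-4-methoxyphenyl from 1-methyl-1H-indazol-6-yl at this carbon (a 1.7-fold lower number from compound 3 to compound 4 (0.23 log units; within the scatter)). That ring alone therefore does not bring back the number of compound 1: the gap to 4-methylphenyl stays large (a 46-fold higher number from compound 1 to compound 4 (1.66 log units; beyond the scatter)), while 3-amino-4-methoxyphenyl still stands well clear of 4-acetylphenyl (a 30-fold lower number from compound 2 to compound 4 (1.47 log units; beyond the scatter)), so the substituents on this ring decide much of the range across compounds 1, 2 and 4. No measured evidence on the origin of these differences is at hand.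

As far as these compounds go, the amino and methoxy groups enter together in compound 4, so the contribution of each remains open, and 3-aminophenyl and 4-methoxyphenyl would separate them. Also open, from the compounds shown here alone, is how far the methyl of 4-methylphenyl can be changed at this carbon, for instance to ethyl, chlorine or a carboxylic acid.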